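The compounds below may be only part of what the source reports. "The series", "measured", "known", "first", "only" and "open" are said of these compounds alone.

Measured compounds in an assay (Cricetulus griseus) for inhibition of Monoamine oxidase (Homo sapiens); a higher number here means a weaker inhibitor, a lower number a stronger inhibitor:
Compound 1 `O=c1c(-c2ccc(O)cc2)coc2cc(OCCCCCCCCCO)ccc12` gives > 9000 nM, a limit of the assay.
Compound 2 `CCOC(=O)CCCCOc1ccc2c(=O)c(-c3ccc(O)cc3)coc2c1` gives > 9000 nM, also a limit of the assay.
Compound 3 `O=C(O)CCCCCCCOc1ccc2c(=O)c(-c3ccc(O)cc3)coc2c1` gives 6500 nM.

Compound 2 stands at the limit, as does compound 1 (the limit of > 9000 nM in this assay, at which 2 of the 3 values shown sit); only compound 3 returns a number. The change to compound 4 `CC(C)Oc1ccc2c(=O)c(-c3ccc(O)cc3)coc2c1` is isopropyl in place of 4-(ethoxycarbonyl)butyl on an oxygen on an aromatic ring. Among the measured compounds shown here, no measured step covers such a change: the steps of an at least 1.3-fold lower number from compound 2 to compound 3 (0.14 log units; that floor lies within the scatter) and an at least 1.3-fold lower number from compound 1 to compound 3 (0.14 log units; that floor lies within the scatter) alter only the end of the chain, and the step that the two limits leave unreadable from compound 1 to compound 2 cannot be read. All values shown sit at or near the limit, so no shift beyond the scatter is expected in this assay, and the estimated step is a number no higher from compound 2 to compound 4 (the limit leaves the size open). Compound 4 is therefore expected around 9000 nM, within 3000 nM to 30000 nM.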

Compound 4, half-maximal inhibitory concentration: 200 nM
For compound 4 the middle estimate is 45-fold (1.65 log units) above the measured one; measured number outside the range, below it.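

In this assay, isopropyl in place of 4-(ethoxycarbonyl)butyl on the oxygen gives an at least 45-fold lower number from compound 2 to compound 4 (1.65 log units; beyond the scatter), the only step shown that is printed as beyond the scatter. The group on this oxygen can therefore move the number strongly, which the changes at the chain end did not show. The true size of the step stays open because compound 2 stands at a limit: the limit of > 9000 nM in this assay, at which 2 of the 4 values shown sit.

This single step does not separate chain length, branching and loss of the ester. On these data alone, whether a straight propyl chain, a methyl group or a short chain ending in an amine would give a similar number also stays open.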